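The compounds below may be only part of what the source reports. "The series", "measured", "known", "first", "only" and "open" are said of these compounds alone.

Compound 1 `CCCn1ncnc1-c1ccccc1NCC1=NCCN1` and compound 2 `CC(C)n1ncnc1-c1ccccc1NCC1=NCCN1` share one core and differ only in the group on the aromatic nitrogen. In an in vitro functional assay on cells (Fibroblast) for agonist activity at Alpha-1A adrenergic receptor (Homo sapiens) (a higher number here means that more compound is needed for the effect, a lower number that less compound is needed), compound 1 gives 12.6 nM, and in this assay compound 2 gives 6.31 nM. The change between them is isopropyl in place of propyl on an aromatic nitrogen, and it made a 2.0-fold lower number from compound 1 to compound 2 (0.30 log units; within the scatter). Compound 3 `CCCn1nccc1-c1ccccc1NCC1=NCCN1` carries a different core; in this assay compound 3 gives 251 nM, the highest number of the three, and the difference between the two cores is not broken down here. Compound 4 `CC(C)n1nccc1-c1ccccc1NCC1=NCCN1` is not yet measured. From compound 3 to compound 4 the change is isopropyl in place of propyl on an aromatic nitrogen. This is the same kind of change as from compound 1 to compound 2, but the place differs: in the core of compound 1 the ring is a five-membered aromatic ring with 3 nitrogen and the site is two ring bonds from the ring nitrogen, whereas in the core of compound 3 the ring is a five-membered aromatic ring with 2 nitrogen. Because compound 1 to compound 2 gave a 2.0-fold lower number from compound 1 to compound 2 (0.30 log units; within the scatter), a step of similar size, within the scatter, is expected here; the expected step is a 1.7-fold lower number from compound 3 to compound 4 (0.22 log units; within the scatter). In this assay compound 4 is estimated at 150 nM, between 60 nM and 400 nM.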

Compound 4, half-maximal effective concentration: < 100000 nM
Compound 4: no number, only a limit; the forecaster's own chance of this, stated with the estimate: 2%; the middle value is on the limit's open side.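

In this assay compound 4 gives < 100000 nM, which is a limit of the assay and not a number. Among the compounds shown here, no step from compound 3 to compound 4 can be read from it. The compounds shown leave open whether isopropyl in place of propyl on an aromatic nitrogen acts in the core of compound 3 as it does in the core of compound 1.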